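Replacing a difluorophenyl amide with a methylpyridinyl amide

This account rests on a few compounds, and the source may have more. Where it says the series, first, only, none or still open, it means among the compounds named here.

Three analogues share one core and differ only in the aryl group on the amide nitrogen. In an in vitro ADME assay on microsomes from liver (Mus musculus) for pharmacokinetics, read by LC-MS, with a stated time of 10 min, tested at 1 uM (on this read-out higher numbers stand for fast clearance and lower numbers for slow clearance), compound 1 `CN1C[C@H](C(=O)Nc2ccc(F)cc2)[C@@H](c2ccc(/C=C/C(=O)Nc3ccccc3N)cc2)C1` gives 34 mL/min/kg, compound 2 `CN1C[C@H](C(=O)Nc2cccc(F)c2)[C@@H](c2ccc(/C=C/C(=O)Nc3ccccc3N)cc2)C1` gives 56 mL/min/kg, and compound 3 `CN1C[C@H](C(=O)Nc2ccc(F)c(F)c2)[C@@H](c2ccc(/C=C/C(=O)Nc3ccccc3N)cc2)C1` gives 46 mL/min/kg, the second highest of the three, with the steps of a 1.6-fold higher number from compound 1 to compound 2 (0.22 log units; within the scatter), a 1.4-fold higher number from compound 1 to compound 3 (0.13 log units; within the scatter) and a 1.2-fold lower number from compound 2 to compound 3 (0.09 log units; within the scatter) all within the scatter. Compound 4 `Cc1ccc(NC(=O)[C@H]2CN(C)C[C@@H]2c2ccc(/C=C/C(=O)Nc3ccccc3N)cc2)cn1` differs from compound 3 by 6-methylpyridin-3-yl in place of 3,4-difluorophenyl on an amide-type nitrogen. Within the data shown here, no measured step exchanges the carbon ring for a ring with a hetero atom, so the three small steps give no direction; compound 4 is expected to show a 1.1-fold lower number from compound 3 to compound 4 (0.04 log units; within the scatter), nothing beyond the scatter. The estimate for compound 4 in this assay is 42 mL/min/kg, between 20 mL/min/kg and 85 mL/min/kg.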

Compound 4, clearance: 57 mL/min/kg
Beside the measured number, compound 4's estimate is 1.4-fold (0.13 log units) below it, within the range that was stated.
By their numbers in this assay, from the lowest: compounds 1, 3, 2 and 4 (each within the scatter of the next).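

This exchange of a carbon-only ring for a ring with a hetero atom on the amide-type nitrogen stays within the scatter in this assay, with a 1.2-fold higher number from compound 3 to compound 4 (0.09 log units; within the scatter), alongside a 1.0-fold higher number from compound 2 to compound 4 (0.01 log units; within the scatter) and a 1.7-fold higher number from compound 1 to compound 4 (0.22 log units; within the scatter). All four aryl groups at this position thus remain within the scatter of the next in the series, and 6-methylpyridin-3-yl stands with the fluorinated rings. No measurement at hand bears on the cause of these numbers. Still open, on these data alone, is what a pyridin-3-yl without the methyl group, or an amine or a carboxylic acid on this ring, would give.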